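The source may report more compounds than this note shows. Statements on the series, on what has been measured and on what is new or still open speak of the compounds shown alone.

For the measured compounds named here, in an ADME assay on MT4 cells (Homo sapiens) for cytotoxicity, read by MTT assay, with a stated time of 5 days (a higher number here means that more compound is tolerated, a lower number that less compound is tolerated), compound 1 (`COc1cc(Oc2cc(C)cc(C)c2)cc(Nc2ccc(C#N)cc2)n1`) gives 20000 nM and compound 2 (`COc1cc(Oc2c(C)cc(C)cc2C)cc(Nc2ccc(C#N)cc2)n1`) gives 29000 nM as one of only two numbers so far, the pair lying within the scatter of each other. Going from compound 2 to compound 3 (`COc1cc(Oc2c(C)cccc2C)cc(Nc2ccc(C#N)cc2)n1`), the change is hydrogen in place of methyl on an aromatic carbon and reads 2,4,6-trimethylphenyl to 2,6-dimethylphenyl, hydrogen in place of methyl on an aromatic carbon. Going by the values given here, only one measured step bears on this, a 1.5-fold higher number from compound 1 to compound 2 (0.16 log units; within the scatter) for 2,4,6-trimethylphenyl in place of 3,5-dimethylphenyl on an oxygen on an aromatic ring. On that single step, no shift beyond the scatter is expected in this assay in either direction. The estimated change is a 1.2-fold lower number from compound 2 to compound 3 (0.06 log units; within the scatter) and stays within the scatter. Compound 3 is estimated at 25000 nM with 12000 nM to 50000 nM as the expected range.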

Compound 3, half-maximal cytotoxic concentration: 8500 nM
Beside the measured number, compound 3's estimate is 2.9-fold (0.47 log units) above it, and the stated range ends above it.
By their numbers in this assay, from the lowest: compound 3; then compounds 1 and 2 (each within the scatter of the next).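

In this assay, for the compounds shown here, hydrogen in place of methyl on the aromatic carbon para to a large group gives a 3.4-fold lower number from compound 2 to compound 3 (0.53 log units; beyond the scatter), the first step beyond the scatter, so the read-out does respond at this position. Set against 3,5-dimethylphenyl, 2,6-dimethylphenyl gives a 2.4-fold lower number from compound 1 to compound 3 (0.37 log units; beyond the scatter), also beyond the scatter, whereas 2,4,6-trimethylphenyl gave a 1.5-fold higher number from compound 1 to compound 2 (0.16 log units; within the scatter), within it, which leaves compound 3 lowest of the three. Nothing measured here accounts for these shifts.

As far as these compounds go, at this aromatic carbon only methyl and hydrogen can be compared so far, so how an amine, a carboxylic acid or a longer chain there would read remains open. Also open, from the compounds shown here alone, is whether the step from methyl to hydrogen would recur with a different group in place of the nitrile on the shared core.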